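This account rests on a few compounds, and the source may have more. Where it says the series, first, only, none or still open, it means among the compounds named here.

The measured compounds so far:

Compound 1, `CC(C)(C)c1ccc(OCCCON2C(N)=NC(N)=NC23CCSCC3)cc1`: 1 nM
Compound 2, `NC1=NC2(CCSCC2)N(OCCCOc2ccc(Br)cc2)C(N)=N1`: 20 nM
Compound 3, `NC1=NC2(CCOCC2)N(OCCCOc2ccc(Br)cc2)C(N)=N1`: 320 nM

All three were tested in a functional assay on HCT-116 cells (Homo sapiens) for antiproliferative activity, read by MTT assay, with a stated time of 72 h; on this read-out lower numbers stand for stronger inhibition and higher numbers for weaker inhibition. Compound 2 and compound 3 carry the same bromo group but differ in their cores; the difference between the two cores is not broken down here, and the two values simply show compound 3 giving the higher number. Compound 1 differs from compound 2 by tert-butyl in place of bromo on an aromatic carbon, and that step gave a 20-fold lower number from compound 2 to compound 1 (1.30 log units; beyond the scatter). Compound 4, `CC(C)(C)c1ccc(OCCCON2C(N)=NC(N)=NC23CCOCC3)cc1`, has not yet been measured. It differs from compound 3 by tert-butyl in place of bromo on an aromatic carbon, the same change at the same place on the ring. The expected step in this assay is a 20-fold lower number from compound 3 to compound 4 (1.30 log units; beyond the scatter), and this expectation rests on the step from compound 2 to compound 1, a 20-fold lower number from compound 2 to compound 1 (1.30 log units; beyond the scatter), being carried over to the core of compound 3. Compound 4 is therefore estimated at 16 nM, expected to lie between 5 nM and 60 nM.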

Compound 4, half-maximal inhibitory concentration: 1610 nM
The estimate for compound 4 lay 100-fold (2.00 log units) below the measured number, and the stated range ends below it.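

Replacing bromo with tert-butyl gave a 5.0-fold higher number from compound 3 to compound 4 (0.70 log units; beyond the scatter) in this assay. Set beside the earlier step, the same change moves the number in opposite directions on the two cores: the same change on two cores in this assay, a 20-fold lower number (1.30 log units; beyond the scatter) from compound 2 to compound 1 and a 5.0-fold higher number (0.70 log units; beyond the scatter) from compound 3 to compound 4, 100-fold (2.00 log units) apart, beyond the scatter of two such steps In these two pairs, the outcome of the change depends on the core, so a step read on one core is no safe guide to the other, but two pairs cannot show why this happens or how any further core would respond.

Still open, as far as these compounds go, is whether groups such as chloro or methyl in place of bromo would also behave differently on the two cores. From the compounds shown here alone, it is equally open whether a longer chain to the aromatic ring would keep this difference.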